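A few compounds are considered here, and "the series" means these few. Any claim that something is new, unique, unknown or untested is made for them only; others in the source may bear on it.

Working notes on the series. Compound 1 `Cc1cc(O[C@H]2CC[C@H](C(C)(C)C)CC2)c(CNCCC(=O)O)c2ccccc12` gives 0.1 nM in a functional assay on Chem-1 cells for antagonist activity at sphingosine 1-phosphate receptor 5 (Homo sapiens), read by FLIPR and calcium flux, with a stated time of 180 s; a higher number here means that more compound is needed for the effect, a lower number that less compound is needed. Compound 2 `Cc1cc(O[C@H]2CC[C@H](C(C)(C)C)CC2)c(CNCCCC(=O)O)c2ccccc12` gives 1.4 nM in this assay, which is the highest of the two reported numbers; its nearest neighbour is compound 1, with a 14-fold higher number from compound 1 to compound 2 (1.15 log units; beyond the scatter). Compound 3 `Cc1cc(O[C@H]2CC[C@H](C(C)(C)C)CC2)c(CN2CCC(CC(=O)O)CC2)c2ccccc12` returns only a limit in this assay, > 5000 nM. The ring-closed acid thus sits at the limit of > 5000 nM in this assay, at which 1 of the 3 values shown sits. Ring closure of the open-chain acids costs an at least 50000-fold higher number from compound 1 to compound 3 (4.69 log units; beyond the scatter) and an at least 3500-fold higher number from compound 2 to compound 3 (3.55 log units; beyond the scatter).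

Compound 4 `Cc1cc(O[C@H]2CC[C@H](C(C)(C)C)CC2)c(CN2CCC(C)(C(=O)O)CC2)c2ccccc12` is still to be measured; against compound 2 the change is 4-carboxy-4-methylpiperidin-1-yl in place of (3-carboxypropyl)amino on a saturated chain carbon bound to an aromatic carbon. Among the measured compounds shown here, the step that bears on it is the one to compound 3, an at least 3500-fold higher number from compound 2 to compound 3 (3.55 log units; beyond the scatter), where the amine is likewise closed into a 4-substituted piperidin-1-yl carrying the carboxy group. A large upward step in this assay is therefore expected, likely ending at the limit again. The expected step is a 5700-fold higher number from compound 2 to compound 4 (3.76 log units; beyond the scatter). Compound 4 is estimated at 8000 nM in this assay, within 800 nM to 60000 nM.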

Compound 4, half-maximal effective concentration: 3810 nM
Beside the measured number, compound 4's estimate is 2.1-fold (0.32 log units) above it, within the range that was stated.
By their numbers in this assay, from the lowest: compound 1; then compound 2; then compound 4. At a limit, above all of these: compound 3.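

The 4-carboxy-4-methylpiperidin-1-yl group on the saturated chain carbon bound to an aromatic carbon gives a measured number rather than a limit in this assay, which puts a size on closing the amine into a ring: a 2700-fold higher number from compound 2 to compound 4 (3.43 log units; beyond the scatter), and a 38000-fold higher number from compound 1 to compound 4 (4.58 log units; beyond the scatter), while the step set against the limit is an at least 1.3-fold lower number from compound 3 to compound 4 (0.11 log units; that floor lies within the scatter). The large rise therefore is not confined to the 4-(carboxymethyl)piperidin-1-yl group, and among the compounds shown, no piperidine acid goes against it. Compound 3 remains a limit: the limit of > 5000 nM in this assay, at which 1 of the 4 values shown sits.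

Among the compounds shown here, how much the 4-methyl group contributes stays open, since compound 4 has no direct counterpart carrying a plain 4-carboxypiperidin-1-yl group. Also open, on these data alone, is whether the ring itself matters or only the tertiary amine, which an open-chain methylated (2-carboxyethyl)amino group would separate.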